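This account rests on a few compounds, and the source may have more. Where it says the series, first, only, none or still open, it means among the compounds named here.

Compound 1 `O=C1C(Nc2ccccc2F)=CC(=O)c2c1nc1n2[C@H]2OC[C@@H](O)[C@H]2OC1` gives 2660 nM in a functional assay on ECa-109 cells for inhibition, with ECa-109 cell line (Homo sapiens) as the target, read by sulforhodamine B assay; a lower number here means a stronger inhibitor, a higher number a weaker inhibitor. Compound 2 `O=C1C=C(N2CCC2)C(=O)c2c1nc1n2[C@H]2OC[C@@H](O)[C@H]2OC1` shows only a limit in this assay, > 16000 nM. So compound 2 stands at the limit of > 16000 nM in this assay, at which 1 of the 2 values shown sits. Compound 3 `Cc1ccc(NC2=CC(=O)c3nc4n(c3C2=O)[C@H]2OC[C@@H](O)[C@H]2OC4)cc1C` awaits measurement in this assay; it differs from compound 2 by (3,4-dimethylphenyl)amino in place of azetidin-1-yl on a double-bonded ring carbon. The step from compound 2 to compound 3 is expected to bring a clear gain in potency, an at least 6.4-fold lower number from compound 2 to compound 3 (0.80 log units; beyond the scatter), because compound 1, which likewise carries an amine bearing an aromatic ring at that place, gives 2660 nM. The estimate for compound 3 in this assay is 2500 nM, within a range from 800 nM to 9000 nM.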

Compound 3, half-maximal inhibitory concentration: 2820 nM
Compound 3: the middle estimate sits 1.1-fold (0.05 log units) below what was measured; the range from low to high includes it.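

In this assay, placing (3,4-dimethylphenyl)amino instead of azetidin-1-yl on the double-bonded ring carbon brings an at least 5.6-fold lower number from compound 2 to compound 3 (0.75 log units; beyond the scatter). Within the data shown here, this gives the first direct comparison at this position, and the two groups are clearly not interchangeable there. The true size of the step stays unknown because compound 2 has only a limit, not an exact value: the limit of > 16000 nM in this assay, at which 1 of the 3 values shown sits.

The compounds shown cannot separate the contribution of the aromatic ring from that of the amine hydrogen. A plain phenylamino group, a benzylamino group or a longer chain such as butylamino at this position would test this further.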